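The source may report more compounds than this note shows. Statements on the series, on what has been measured and on what is new or still open speak of the compounds shown alone.

In a functional assay on MIA PaCa-2 cells (Homo sapiens) for cytotoxicity, read by MTT assay, with a stated time of 72 h (on this read-out lower numbers stand for stronger inhibition and higher numbers for weaker inhibition), compound 1 (`O=C1C(Nc2ccc(-c3ccc(Cl)cc3)cc2)=CC(=O)c2ncncc21`) gives 9700 nM, compound 2 (`O=C1C(Nc2ccc(C3CCCCC3)cc2)=CC(=O)c2ncncc21`) gives 1200 nM and compound 3 (`O=C1C(Nc2ccc(N3CCCCC3)cc2)=CC(=O)c2ncncc21`) gives 2400 nM. Compound 3 thus stands clear of compound 1, with a 4.0-fold lower number from compound 1 to compound 3 (0.61 log units; beyond the scatter), but not of compound 2, with a 2.0-fold higher number from compound 2 to compound 3 (0.30 log units; within the scatter). Compound 4 (`O=C1C(Nc2ccc(-c3cc(Cl)cc(Cl)c3)cc2)=CC(=O)c2ncncc21`) carries 3,5-dichlorophenyl in place of piperidin-1-yl on an aromatic carbon. Among the measured compounds shown here, the closest evidence is compound 1, the only measured compound with a chlorinated phenyl group in this place, which shows a 4.0-fold lower number from compound 1 to compound 3 (0.61 log units; beyond the scatter) and an 8.1-fold lower number from compound 1 to compound 2 (0.91 log units; beyond the scatter). A modest move to a higher number, about the size of the first of these steps, is therefore expected. The expected step is a 3.3-fold higher number from compound 3 to compound 4 (0.52 log units; beyond the scatter). For compound 4 the estimated value is 8000 nM, within a range of 3500 nM to 18000 nM.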

Compound 4, half-maximal inhibitory concentration: 3100 nM
Estimate against measurement, compound 4: 2.6-fold (0.41 log units) above; measured number outside the range, below it.
By their numbers in this assay, from the lowest: compounds 2, 3 and 4 (each within the scatter of the next, the first and the last beyond it); then compound 1.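

In this assay, a phenyl group at this place does not by itself set the number apart from the non-aromatic piperidin-1-yl group (a 1.3-fold higher number from compound 3 to compound 4 (0.11 log units; within the scatter)), although 3,5-dichlorophenyl still stands clear of cyclohexyl (a 2.6-fold higher number from compound 2 to compound 4 (0.41 log units; beyond the scatter)). The two chlorinated phenyl groups are also not interchangeable here (a 3.1-fold lower number from compound 1 to compound 4 (0.50 log units; beyond the scatter)). No evidence is available to explain these differences. Going by these compounds, it remains open where an unsubstituted phenyl group would fall, and how a morpholin-4-yl group or a carboxylic acid would compare at this place.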